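This account rests on a few compounds, and the source may have more. Where it says the series, first, only, none or still open, it means among the compounds named here.

Measured in a functional assay on HeLa cells (Homo sapiens) for cytotoxicity, read by MTT assay, with a stated time of 72 h; on this read-out higher numbers stand for weaker inhibition and lower numbers for stronger inhibition:

compound 1 `O=C(c1ccccc1C(F)(F)F)N(/N=N/c1ccc([N+](=O)[O-])cc1Cl)c1ccc([N+](=O)[O-])cc1Cl`: 10600 nM
compound 2 `O=C(c1cccc(C(F)(F)F)c1)N(/N=N/c1ccc([N+](=O)[O-])cc1Cl)c1ccc([N+](=O)[O-])cc1Cl`: 1180 nM
compound 3 `O=C(c1cccc(F)c1)N(/N=N/c1ccc([N+](=O)[O-])cc1Cl)c1ccc([N+](=O)[O-])cc1Cl`: 2500 nM

Compound 3 holds the second highest of the three numbers in this assay. Its nearest neighbour is compound 2, with a 2.1-fold higher number from compound 2 to compound 3 (0.33 log units; beyond the scatter); the furthest is compound 1, with a 4.2-fold lower number from compound 1 to compound 3 (0.63 log units; beyond the scatter).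

Compound 4 `CC(=O)OCC(=O)N(/N=N/c1ccc([N+](=O)[O-])cc1Cl)c1ccc([N+](=O)[O-])cc1Cl` differs from compound 3 in one place: acetoxymethyl in place of 3-fluorophenyl on a carbonyl carbon. The three measured steps all exchange one substituted phenyl for another on the carbonyl carbon and keep a six-membered aromatic ring there: a 9.0-fold lower number from compound 1 to compound 2 (0.95 log units; beyond the scatter), a 4.2-fold lower number from compound 1 to compound 3 (0.63 log units; beyond the scatter), a 2.1-fold higher number from compound 2 to compound 3 (0.33 log units; beyond the scatter). For the measured compounds named here, none of them removes the ring or brings in a chain, so the change to compound 4 has no direct precedent. What the measured steps do show is that the group on the carbonyl carbon moves the number in this assay by modest amounts in either direction, and the whole series stays within a narrow range. Going by the values given here, with no step of the same kind to lean on, the expectation for compound 4 is a number in this assay near the middle of the measured range, with a wide band; the expected step is a 2.0-fold higher number from compound 3 to compound 4 (0.30 log units; within the scatter). Compound 4 is estimated at 5000 nM, between 1000 nM and 30000 nM.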

Compound 4, half-maximal inhibitory concentration: 350 nM
Estimate against measurement, compound 4: 14-fold (1.15 log units) above, outside the stated range (below it).
By their numbers in this assay, from the lowest: compound 4; then compound 2; then compound 3; then compound 1.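

In this assay the carbonyl carbon does not need an aromatic ring: acetoxymethyl, which has no ring, in place of 3-fluorophenyl gives a 7.1-fold lower number from compound 3 to compound 4 (0.85 log units; beyond the scatter) and in place of 3-(trifluoromethyl)phenyl gives a 3.4-fold lower number from compound 2 to compound 4 (0.53 log units; beyond the scatter) while in place of 2-(trifluoromethyl)phenyl it gives a 30-fold lower number from compound 1 to compound 4 (1.48 log units; beyond the scatter) as the largest step in the series. Compound 4 thus holds the lowest number of the four, with all three steps beyond the scatter, so the best group at this position among those shown is a ring-free one rather than a substituted phenyl. Nothing at hand accounts for this gain or separates the loss of the ring from the arrival of the ester.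

Compound 4 is the only ring-free member shown, so it remains open whether the ester matters or whether a plain chain would serve as well. A methyl, a hydroxymethyl, a carboxylic acid or a longer chain with the ester kept on the same carbonyl carbon would separate these readings.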